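The compounds below may be only part of what the source reports. "The series", "measured", "known", "first", "only" and "open" are said of these compounds alone.

Measured compounds in an assay on COS7 cells for inhibition of Ectonucleotide pyrophosphatase/phosphodiesterase family member 1 (Homo sapiens), with a stated time of 35 min; a higher number here means a weaker inhibitor, a lower number a stronger inhibitor:
compound 1 `O=C(NS(=O)(=O)c1ccc(Cl)cc1)n1ccc2cccnc21` gives 10400 nM;
compound 2 `O=C(NS(=O)(=O)c1cccc([N+](=O)[O-])c1)n1ccc2cccnc21` gives 800 nM;
compound 3 `O=C(NS(=O)(=O)c1ccccc1)n1ccc2cc(Br)cnc21` gives 8300 nM.

Among these three numbers compound 2 stands lowest, the strongest inhibitor of the set; compound 3 stands next and compound 1 still further off, both gaps beyond the scatter. Compound 4 `O=C(NS(=O)(=O)c1cccc([N+](=O)[O-])c1)n1ccc2cc(Br)cnc21` has not yet been measured. It keeps the nitro-bearing ring of compound 2 and differs from it in one place: bromo in place of hydrogen on an aromatic carbon. Within the data shown here, no pair of measured compounds shows this one change alone, since compounds 1 and 3 differ from each other in two places, so its size is unknown. The expectation is for a step from compound 2 to compound 4 in this assay of a 1.3-fold lower number from compound 2 to compound 4 (0.12 log units; within the scatter), small and not beyond the scatter. Compound 4 is therefore expected to give about 600 nM, within a range from 150 nM to 2500 nM.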

Compound 4, half-maximal inhibitory concentration: 1150 nM
Compound 4: the middle estimate sits 1.9-fold (0.28 log units) below what was measured; measured number inside the range.
By their numbers in this assay, from the lowest: compounds 2 and 4 (each within the scatter of the next); then compounds 3 and 1 (each within the scatter of the next).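

Bromo in place of hydrogen on this aromatic carbon, two atoms from the ring nitrogen, can now be read alone in this assay: the step is a 1.4-fold higher number from compound 2 to compound 4 (0.16 log units; within the scatter) and so shows no real change at this position. With the bromo in place, nitro in place of hydrogen on the other ring gives a 7.2-fold lower number from compound 3 to compound 4 (0.86 log units; beyond the scatter) and so does move the number. Nothing measured here offers a reason for either step.

Going by these compounds, whether an amine, a carboxylic acid or a longer chain on the same carbon would shift the number beyond the scatter stays open. So does whether the bromo step stays this small without the nitro group.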